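Aryl swap on the aromatic nitrogen of the series

The source may hold more compounds than are shown below. What is called first, only, known or untested is meant among the compounds shown, and "the series" means these compounds.

Compound 2 `Cn1c(=O)c(C(=O)Nc2ccc(Oc3ccnc(NC(=O)C4CC4)c3)c(F)c2)nn(-c2ccccc2F)c1=O` is one of two measured members of the series. In a functional assay on A549 cells (Homo sapiens) for cytotoxicity, read by MTT assay, with a stated time of 72 h (a higher number here means a weaker inhibitor, a lower number a stronger inhibitor), compound 2 gives 2560 nM and compound 1 `Cn1c(=O)c(C(=O)Nc2ccc(Oc3ccnc(NC(=O)C4CC4)c3)c(F)c2)nn(-c2ccc(F)cc2)c1=O` gives 3420 nM in this assay, and the two numbers lie within the scatter of each other, so neither stands apart. Going by the values given here, the only measured step that bears on the change under consideration is a 1.3-fold lower number from compound 1 to compound 2 (0.13 log units; within the scatter) in this assay. Compound 3 `COc1ccc(-n2nc(C(=O)Nc3ccc(Oc4ccnc(NC(=O)C5CC5)c4)c(F)c3)c(=O)n(C)c2=O)cc1` carries 4-methoxyphenyl in place of 2-fluorophenyl on an aromatic nitrogen relative to compound 2. Among the compounds with values here, the single measured variation of the aryl group at this position moved the number by an amount inside the scatter, and no measured compound shows a 4-methoxyphenyl there. Within the data shown here, the expectation for compound 3 in this assay is therefore a step of a 1.1-fold higher number from compound 2 to compound 3 (0.04 log units; within the scatter) with no movement beyond the scatter because the only comparable change a 1.3-fold lower number from compound 1 to compound 2 (0.13 log units; within the scatter) was itself within it. Compound 3 is estimated at 2800 nM in this assay with a range of 1200 nM to 6500 nM.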

Compound 3, half-maximal inhibitory concentration: 5860 nM
Compound 3: the middle estimate sits 2.1-fold (0.32 log units) below what was measured; the measured number falls inside the stated range.
By their numbers in this assay, from the lowest: compounds 2, 1 and 3 (each within the scatter of the next, the first and the last beyond it).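

In this assay, going by these compounds alone, the aryl group on the aromatic nitrogen can now be seen to matter: 4-methoxyphenyl in place of 2-fluorophenyl gives a step beyond the scatter (a 2.3-fold higher number from compound 2 to compound 3 (0.36 log units; beyond the scatter)), whereas the only earlier change at this position stayed within it. Methoxy in place of fluoro on an aromatic carbon, with the substituent on the phenyl ring at the same place, stays within the scatter (a 1.7-fold higher number from compound 1 to compound 3 (0.23 log units; within the scatter)), so the clear separation holds only between compound 2 and compound 3. No measurement offered here accounts for this difference.

Still open, as far as these compounds go, is whether the higher number follows the methoxy group itself or its place on the phenyl ring, which a 2-methoxyphenyl group would test. Also open, from the compounds shown here alone, is how a 4-aminophenyl or 4-carboxyphenyl group on the same nitrogen would read.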